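Swapping One Ring Substituent in a Protease Inhibitor Series

The source may hold more compounds than are shown below. What is called first, only, known or untested is meant among the compounds shown, and "the series" means these compounds.

Measured compounds:
- compound 1, `N=C(N)c1cccc(C2=NO[C@H](Cn3cnnn3)[C@H]2C(=O)Nc2ccc(-c3ccccc3S(N)(=O)=O)cc2)c1`: 180 nM
- compound 2, `N=C(N)c1cccc(-c2noc(C(F)(F)F)c2C(=O)Nc2ccc(-c3ccccc3S(N)(=O)=O)cc2)c1`: 400 nM

Both compounds were tested in an assay on isolated protein for inhibition of serine protease 1 (Bos taurus); a higher number here means a weaker inhibitor, a lower number a stronger inhibitor. In this assay compound 1 gives 180 nM, and compound 2 gives 400 nM. Of the two, compound 2 has the higher number, so it is the weaker inhibitor, and its gap to compound 1 lies beyond the usual scatter. The two compounds differ in more than one place, so this gap cannot be tied to any single change.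

Compound 3, `COCc1onc(-c2cccc(C(=N)N)c2)c1C(=O)Nc1ccc(-c2ccccc2S(N)(=O)=O)cc1`, has not yet been measured. It differs from compound 2 in one place: methoxymethyl in place of trifluoromethyl on an aromatic carbon. For the measured compounds named here, no measured pair differs in just this group, so there is no direct precedent for the swap. The expected step from compound 2 to compound 3 is no change at the digits printed from compound 2 to compound 3 (within the scatter), which is not beyond the scatter in either direction. Compound 3 is therefore estimated at 400 nM, with a likely range from 130 nM to 1300 nM.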

Compound 3, inhibition constant: 76 nM
The estimate for compound 3 lay 5.3-fold (0.72 log units) above the measured number; measured number below the stated range.
By their numbers in this assay, from the lowest: compound 3; then compound 1; then compound 2.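

In this assay, putting methoxymethyl in place of trifluoromethyl on this aromatic carbon gives a 5.3-fold lower number from compound 2 to compound 3 (0.72 log units; beyond the scatter) and that step lies beyond the usual scatter, so the group at this position does matter for this protease. This is the only step among the compounds shown that isolates a single change, and here the entering group has a hydrogen-bond acceptor while the leaving group has none. Nothing measured here explains the lower number.

The compounds shown leave open whether the lower number goes with the oxygen of methoxymethyl or with the loss of fluorine. An ethyl group, which has neither oxygen nor fluorine, or a longer ether chain at this carbon would help to separate those two readings.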